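Heteroaryl swap at the branched carbon: compound 4

The compounds below may be only part of what the source reports. "The series", "measured", "known", "first", "only" and "open" are said of these compounds alone.

The three measured compounds share one core and vary only in the group on a saturated chain carbon bound to an aromatic carbon and a saturated chain carbon. Compound 1 `CC(C)C(c1noc(=O)[nH]1)c1ccc(-c2ccc3cccc(F)c3c2)[nH]c1=O` gives 15 nM in an assay on CHO cells for displacement of a labelled ligand from prostaglandin E2 receptor EP3 subtype (Homo sapiens), read by radioligand binding; a higher number here means a weaker inhibitor, a lower number a stronger inhibitor. Compound 2 `CC(C)C(/C=C1/CCNC1=O)c1ccc(-c2ccc3cccc(F)c3c2)[nH]c1=O` gives 5.3 nM in this assay, and compound 3 `CC(C)C(c1cnc(N)s1)c1ccc(-c2ccc3cccc(F)c3c2)[nH]c1=O` gives 16 nM. Compound 3 stands alongside compound 1, the gap being a 1.1-fold higher number from compound 1 to compound 3 (0.03 log units; within the scatter), and apart from compound 2 by a 3.0-fold higher number from compound 2 to compound 3 (0.48 log units; beyond the scatter); the related step of a 2.8-fold lower number from compound 1 to compound 2 (0.45 log units; beyond the scatter) points the same way, the non-aromatic ring with 1 hetero atom giving the lowest number of the set.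

Compound 4 `Cc1c[nH]c(C(c2ccc(-c3ccc4cccc(F)c4c3)[nH]c2=O)C(C)C)n1` is not yet measured. It differs from compound 3 in one place: 4-methyl-1H-imidazol-2-yl in place of 2-amino-1,3-thiazol-5-yl on a saturated chain carbon bound to an aromatic carbon and a saturated chain carbon. The step that bears most directly on this change is the exchange of one five-membered aromatic ring for another between compound 1 and compound 3, where the number hardly moved (a 1.1-fold higher number from compound 1 to compound 3 (0.03 log units; within the scatter)). The change to compound 4 is again an exchange of one five-membered aromatic ring with 2 hetero atoms for another, so the step of a 1.1-fold lower number from compound 3 to compound 4 (0.06 log units; within the scatter) in this assay is expected to stay within the scatter. Compound 4 is therefore estimated at 14 nM, in the range 5 nM to 40 nM.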

Compound 4, inhibition constant: 12 nM
Estimate against measurement, compound 4: 1.2-fold (0.07 log units) above; measured number inside the range.
By their numbers in this assay, from the lowest: compound 2; then compounds 4, 1 and 3 (each within the scatter of the next).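

In this assay, 4-methyl-1H-imidazol-2-yl on this saturated chain carbon sits level with both earlier five-membered aromatic rings (a 1.3-fold lower number from compound 3 to compound 4 (0.12 log units; within the scatter); a 1.3-fold lower number from compound 1 to compound 4 (0.10 log units; within the scatter)). Compounds 1, 3 and 4 now make a flat group of three rings with different atom sets, and the swap of 2-amino-1,3-thiazol-5-yl for a methyl-bearing ring of carbon and nitrogen alone, with no sulfur, leaves the number within the scatter. The gap to the non-aromatic lactam-bearing group of compound 2 also holds against this third aromatic ring (a 2.3-fold higher number from compound 2 to compound 4 (0.35 log units; beyond the scatter)), so among these four compounds only compound 2 stands apart, and no aromatic ring shown here closes that gap.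

No data are available to explain either the level numbers of compounds 1, 3 and 4 or the gap to compound 2. Still open, as far as these compounds go, is whether the imidazole without its methyl group, a carboxylic acid, or an open-chain amide on the same carbon would stay with compounds 1, 3 and 4 or come closer to compound 2.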